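The source may report more compounds than this note shows. Statements on the series, on what has been measured and on what is new or still open speak of the compounds shown alone.

Measured so far:
Compound 1, `CN1CCN(CCCNCc2cn(-c3ccc([N+](=O)[O-])cc3)nc2-c2ccc(C(F)(F)F)cc2)CC1`: 4900 nM
Compound 2, `Cc1ccccc1-c1nn(-c2ccc(OC(F)(F)F)cc2)cc1CNCCN1CCN(C)CC1`: 17000 nM

Both compounds were tested in an ADME assay on Huh-7 cells (Homo sapiens) for cytotoxicity; a lower number here means that less compound is tolerated, a higher number that more compound is tolerated. Compound 2 stands at the higher of the two numbers, and its gap to compound 1 lies beyond the usual scatter, so more of compound 2 is tolerated by the cells than of compound 1.

Compound 3, `Cc1ccccc1-c1nn(-c2ccc([N+](=O)[O-])cc2)cc1CNCCN1CCN(C)CC1`, has not been measured yet. It differs from compound 2 in one place: nitro in place of trifluoromethoxy on an aromatic carbon. Among the measured compounds shown here, no pair of measured compounds differing in a single place is available, so there is no measured step to lean on for this kind of change. Compound 3 shares its nitro group on the same ring with compound 1, but the two also differ elsewhere, so the value of compound 1, 4900 nM, only loosely hints at the direction.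

On that basis a modest step downward in this assay is expected from compound 2 to compound 3, a 1.7-fold lower number from compound 2 to compound 3 (0.23 log units; within the scatter), though a change within the scatter would not be surprising. Compound 3 is therefore estimated at 10000 nM, within a range of 3500 nM to 30000 nM.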

Compound 3, half-maximal cytotoxic concentration: > 20000 nM
Compound 3 was reported as a limit (the forecaster's own chance of this, stated with the estimate: 10%); middle value at least 2.0-fold (0.30 log units) from the limit.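

In this assay compound 3 gives > 20000 nM, which is a limit of the assay and not a number. Going from 4-(trifluoromethoxy)phenyl to 4-nitrophenyl, on an aromatic carbon para to a large group, gives an at least 1.1-fold higher number from compound 2 to compound 3 (0.07 log units; that floor lies within the scatter), so on this core the nitro group does not lower the number compared with trifluoromethoxy. The true size of the step cannot be read, because the reading ends at a limit: the limit of > 20000 nM in this assay, at which 1 of the 3 values shown sits.

The compounds shown leave open how an amine or a carboxylic acid at this same position would fare in the cells. They also do not tell whether a nitrile or a plain hydrogen there would keep the number as high as the nitro group does.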